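Acetyl removal on the lactone side chain across two cores

The source may report more compounds than this note shows. Statements on the series, on what has been measured and on what is new or still open speak of the compounds shown alone.

Of the compounds shown here, three have been measured in a functional assay on ASK cells (Rattus norvegicus) for cytotoxicity, read by sulforhodamine B assay; a lower number here means that less compound is needed, a higher number that more compound is needed for the effect: compound 1 `C=C1CC[C@@H]2[C@](C)(CO)[C@H](OC(C)=O)CC[C@@]2(C)[C@@H]1C/C=C1/C(=O)OC[C@H]1O`, compound 2 `C=C1CC[C@@H]2[C@](C)(CO)[C@H](OC(C)=O)CC[C@@]2(C)[C@@H]1C/C=C1/C(=O)OC[C@H]1OC(C)=O` and compound 3 `C=C1CC[C@@H]2[C@](C)(CO[Si](C)(C)C(C)(C)C)[C@H](O)CC[C@@]2(C)[C@@H]1C/C=C1/C(=O)OC[C@H]1OC(C)=O`. In this assay compound 1 gives 58.1 uM, compound 2 gives 11.5 uM and compound 3 gives 3.41 uM, the lowest of the three. The change from compound 2 to compound 1, (hydrogen in place of acetyl on an oxygen on a saturated carbon), made a 5.1-fold higher number from compound 2 to compound 1 (0.70 log units; beyond the scatter). Compound 4 `C=C1CC[C@@H]2[C@](C)(CO[Si](C)(C)C(C)(C)C)[C@H](O)CC[C@@]2(C)[C@@H]1C/C=C1/C(=O)OC[C@H]1O` carries the same change relative to compound 3, (hydrogen in place of acetyl on an oxygen on a saturated carbon), at the same place. Going by the values given here, how the core of compound 3 differs from that of compound 2 is not broken down here; the two values show only that compound 3 sits lower. Because the earlier step was a 5.1-fold higher number from compound 2 to compound 1 (0.70 log units; beyond the scatter), a step of similar size is expected here, a 4.4-fold higher number from compound 3 to compound 4 (0.64 log units; beyond the scatter), with wider uncertainty since the cores differ. Compound 4 is expected at 15 uM, between 5 uM and 45 uM.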

Compound 4, concentration for half-maximal effect: 15.5 uM
The estimate for compound 4 lay 1.0-fold (0.01 log units) below the measured number; low and high end bracket the measured number.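

In this assay the change from acetoxy to hydroxy, on an oxygen on a saturated carbon, gives a 4.5-fold higher number from compound 3 to compound 4 (0.66 log units; beyond the scatter) and matches the earlier step in size: the same change on two cores in this assay, a 5.1-fold higher number (0.70 log units; beyond the scatter) from compound 2 to compound 1 and a 4.5-fold higher number (0.66 log units; beyond the scatter) from compound 3 to compound 4, 1.1-fold (0.05 log units) apart, within the scatter of two such steps. On these two cores, the change therefore carries over with no difference beyond the scatter, and the acetylated compound has the lower number in each pair. Two matched pairs in one cell assay do not show that the step would hold on any further core, and they do not explain it.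

The compounds shown leave open whether a longer acyl chain such as butanoyl, or a methyl ether, on the same oxygen would behave like acetyl or like hydroxy. On these data alone, compound 2 and compound 3 differ in more than one place, so the contribution of each difference also remains open.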